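Swapping the aryl group on compound 1's piperazine

The source may hold more compounds than are shown below. What is called first, only, known or untested is meant among the compounds shown, and "the series" means these compounds.

Measured so far:
compound 1 `O=c1oc2cccnc2n1CN1CCN(c2ccc(Cl)cc2)CC1` — 10.6 mg/kg
compound 2 `CCN(CC)CCn1c(=O)oc2cccnc21` — only a limit, > 25 mg/kg
compound 3 `O=c1oc2cccnc2n1CCN1CCN(c2ccc(Oc3ccccc3)cc2)CC1` — only a limit, > 50 mg/kg

Within the data shown here, in a functional assay on the whole organism with Mus musculus as the target (on this read-out higher numbers stand for an effect only at larger amounts of compound and lower numbers for an effect already at smaller amounts), compound 1 gives 10.6 mg/kg, the only real number among the three. Compound 2 reaches only a limit of the assay, > 25 mg/kg. Compound 3 also reaches only a limit of the assay, > 50 mg/kg. Compound 4 `COc1ccccc1N1CCN(Cn2c(=O)oc3cccnc32)CC1` has not yet been tested; its change from compound 1 is 2-methoxyphenyl in place of 4-chlorophenyl on an amine nitrogen in a ring. Among the measured compounds shown here, no measured pair shows what such a swap does, so the expected step of a 1.4-fold higher number from compound 1 to compound 4 (0.15 log units; within the scatter) is small and likely within the usual scatter, perhaps slightly toward larger doses. Compound 4 is expected to give 15 mg/kg, with a range from 5 mg/kg to 50 mg/kg.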

Compound 4, dose for half-maximal effect: > 25 mg/kg
Compound 4 was reported as a limit; the forecaster's own chance of this, stated with the estimate: 30%; middle value at least 1.6-fold (0.22 log units) from the limit.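

In this assay, putting 2-methoxyphenyl in place of 4-chlorophenyl on the amine nitrogen in the ring gives an at least 2.3-fold higher number from compound 1 to compound 4 (0.37 log units; beyond the scatter). Among these compounds, this is the first sign that the aryl group at this position matters, since the two compounds differ nowhere else. The true size of the step stays unknown because compound 4 sits at a limit of the assay: the limit of > 25 mg/kg in this assay, at which 2 of the 4 values shown sit.

The compounds shown leave open how a plain phenyl or a pyridyl group would fare on this nitrogen. They also cannot separate losing the chlorine from gaining the methoxy group.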